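A few compounds are considered here, and "the series" means these few. Any claim that something is new, unique, unknown or untested is made for them only; others in the source may bear on it.

Compound 1 `COc1ccc(Cn2nc(Nc3cc(C)[nH]n3)c3ccccc3c2=O)cc1` carries a 4-methoxyphenyl group on a saturated chain carbon bound to an aromatic nitrogen of the shared core. In a functional assay on MCF7 cells (Homo sapiens) for cytotoxicity (a lower number here means a stronger inhibitor, a higher number a weaker inhibitor), compound 1 gives > 30000 nM, which is a limit of the assay and not a number. Compound 1 thus stands at the limit of > 30000 nM in this assay, at which 2 of the 3 values shown sit. Compound 2 `Cc1cc(Nc2nn(Cc3cccnc3)c(=O)c3ccccc23)n[nH]1`, with pyridin-3-yl on the saturated chain carbon bound to an aromatic nitrogen, gives 13400 nM in this assay. Compound 3 `Cc1cc(Nc2nn(C)c(=O)c3ccccc23)n[nH]1`, with hydrogen on that carbon, gives > 30000 nM, again a limit. The measured steps read an at least 2.2-fold lower number from compound 1 to compound 2 (0.35 log units; beyond the scatter) and an at least 2.2-fold higher number from compound 2 to compound 3 (0.35 log units; beyond the scatter), while a step that the two limits leave unreadable from compound 1 to compound 3.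

Compound 4 `Cc1cc(Nc2nn(Cc3ccc([N+](=O)[O-])cc3)c(=O)c3ccccc23)n[nH]1` differs from compound 1 by nitro in place of methoxy on an aromatic carbon. Going by the values given here, none of the measured steps changes a substituent on the phenyl ring; the steps that bear on this change only replace the whole aryl group, and of these only the change to pyridin-3-yl in compound 2 moved the number away from the limit. Compound 1 itself gives only a limit, so any step from it can be read in one direction alone. Nitro in place of methoxy is expected to give no step beyond the scatter, with some chance of a modest lowering. Compound 4 is therefore estimated at 25000 nM, between 8000 nM and 60000 nM in this assay. The expected at least 1.2-fold lower number from compound 1 to compound 4 (0.07 log units; that floor lies within the scatter) is accordingly small.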

Compound 4, half-maximal inhibitory concentration: > 30000 nM
Compound 4 ended at the assay's limit; the forecaster's own chance of this, stated with the estimate: 55%; at least 1.2-fold (0.07 log units) between middle value and limit.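

Changing the para substituent from methoxy to nitro leaves this position at the limit: in this assay compound 4 gives > 30000 nM, which is a limit of the assay and not a number. The change from pyridin-3-yl to 4-nitrophenyl on the saturated chain carbon gives an at least 2.2-fold higher number from compound 2 to compound 4 (0.35 log units; beyond the scatter), so pyridin-3-yl now stands apart from two substituted phenyl groups and not only from 4-methoxyphenyl. The steps from compound 1 and from compound 3 to compound 4 cannot be read, and the swap of methoxy for nitro therefore has no measurable size here, only a shared position at the limit: the limit of > 30000 nM in this assay, at which 3 of the 4 values shown sit.

Going by these compounds alone, compound 2 remains the only compound here with a value that is a number, so how far compound 1, compound 3 and compound 4 lie past the limit stays open. Also open, on these data alone, is whether the lower number belongs to pyridin-3-yl alone, a question that unsubstituted phenyl or pyridin-4-yl on the same carbon, or an amine or a carboxylic acid in place of the nitro, would bear on.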